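One Methyl, Retraced on the Lowest Measured Compound

The source may hold more compounds than are shown below. What is called first, only, known or untested is meant among the compounds shown, and "the series" means these compounds.

Measured so far in a functional assay on SK-MEL-2 cells (Homo sapiens) for cytotoxicity; on this read-out lower numbers stand for stronger inhibition and higher numbers for weaker inhibition: compound 1 `O=C1NC(c2ccccc2)CN1S(=O)(=O)c1ccccc1` gives 116000 nM; compound 3 `Cc1ccc(S(=O)(=O)N2CC(c3ccccc3)NC2=O)cc1` gives 2530 nM; compound 2 `O=C1NC(c2ccccc2)CN1S(=O)(=O)c1ccc2c(c1)CCC2` gives 2 nM.

Compound 4 `Cc1ccc(C2CN(S(=O)(=O)c3ccc4c(c3)CCC4)C(=O)N2)cc1` awaits measurement in this assay. It differs from compound 2 by methyl in place of hydrogen on an aromatic carbon. The same change separates compound 1 from compound 3, where it made a 46-fold lower number from compound 1 to compound 3 (1.66 log units; beyond the scatter). How the core of compound 1 differs from the core of compound 2 is not broken down here; their values simply show compound 2 far lower, and compound 2 is the lowest of the three measured numbers. Because compound 2 already gives 2 nM there is little room left, so a smaller step than the earlier one is expected, namely a 2.0-fold lower number from compound 2 to compound 4 (0.30 log units; within the scatter). Compound 4 is therefore estimated at 1 nM, expected to fall between 0.3 nM and 5 nM.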

Compound 4, half-maximal inhibitory concentration: 72500 nM
Estimate against measurement, compound 4: 73000-fold (4.86 log units) below; measured number above the stated range.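

In this assay, methyl in place of hydrogen on an aromatic carbon gave a 36000-fold higher number from compound 2 to compound 4 (4.56 log units; beyond the scatter) and so did not carry over from one core to the other, not even in direction: the same change on two cores in this assay, a 46-fold lower number (1.66 log units; beyond the scatter) from compound 1 to compound 3 and a 36000-fold higher number (4.56 log units; beyond the scatter) from compound 2 to compound 4, 1700000-fold (6.22 log units) apart, beyond the scatter of two such steps

For these two pairs, then, what the methyl does depends on the core that carries it. The data do not show which feature of the two cores accounts for this, and two pairs give no rule for a third core.

The compounds shown carry only hydrogen or methyl at this place on the phenyl ring. Going by these compounds, it remains open how an ethyl group, a methoxy group, a chlorine atom or an amine would behave there on either core.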